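Extending a meta-bromo amide into a biaryl

The source may report more compounds than this note shows. Statements on the series, on what has been measured and on what is new or still open speak of the compounds shown alone.

A small series of benzoxaborole propanamides was examined in a functional assay on SK-OV-3 cells (Homo sapiens) for antiproliferative activity, read by MTT assay, with a stated time of 72 h; on this read-out lower numbers stand for stronger inhibition and higher numbers for weaker inhibition. Compound 1 `O=C(CCc1cccc2c1B(O)OC2)Nc1ccc(F)cc1` gives 720 nM, and compound 2 `O=C(CCc1cccc2c1B(O)OC2)Nc1cccc(Br)c1` gives 540 nM. Within the data shown here, the only step measured so far, a 1.3-fold lower number from compound 1 to compound 2 (0.12 log units; within the scatter), is within the scatter, so compound 2 and compound 1 cannot be told apart on these numbers; compound 2 simply stands as one of two closely spaced values.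

Compound 3 `O=C(CCc1cccc2c1B(O)OC2)Nc1cccc(-c2cccc(Cl)c2)c1` is not yet measured. It differs from compound 2 in one place: 3-chlorophenyl in place of bromo on an aromatic carbon. Among the measured compounds shown here, this change is larger than anything in the measured set, and no measured step speaks to it directly; the only available step, a 1.3-fold lower number from compound 1 to compound 2 (0.12 log units; within the scatter), compares two small substituents on the amide nitrogen's aryl ring and says nothing about adding a second aromatic ring. The expectation for compound 3 therefore rests on weak ground. Compound 3 is estimated at 400 nM in this assay, with a range of 100 nM to 1600 nM, which corresponds to an expected step of a 1.4-fold lower number from compound 2 to compound 3 (0.13 log units; within the scatter), not clearly beyond the scatter in either direction.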

Compound 3, half-maximal inhibitory concentration: 300 nM
Estimate against measurement, compound 3: 1.3-fold (0.12 log units) above; the range from low to high includes it.
By their numbers in this assay, from the lowest: compounds 3, 2 and 1 (each within the scatter of the next, the first and the last beyond it).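

In this assay, the aromatic carbon that carries the bromo group in compound 2 also takes a much larger group: 3-chlorophenyl brings seven heavy atoms and a six-membered aromatic ring of carbon only in place of a single bromine, and the measurement gives a 1.8-fold lower number from compound 2 to compound 3 (0.26 log units; within the scatter). Among these compounds, this is the first look at a second aromatic ring on the amide's aryl group, and it shows that this much added bulk at this place does not carry the number outside the scatter of compound 2, so the two compounds cannot be told apart and the new ring can be said neither to help nor to harm. Nothing available explains why the number stays within that scatter.

The compounds shown leave open whether the chlorine matters to this result, or whether a plain phenyl in place of the 3-chlorophenyl would read the same. They also leave open how the number in this assay would respond to an amine or a carboxylic acid on the added ring, or to a pyridine in place of it.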